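The compounds below may be only part of what the source reports. "The series", "measured", "known", "first", "only" and "open" are said of these compounds alone.

In a functional assay on BGC-823 cells (Homo sapiens) for cytotoxicity, read by MTT assay, with a stated time of 48 h (a lower number here means a stronger inhibitor, a higher number a weaker inhibitor), compound 1 `O=C(CSc1nnc(-c2ccncc2)o1)N/N=C/c1ccc(Cl)cc1` gives 20500 nM and compound 2 `O=C(CSc1nnc(-c2ccncc2)o1)N/N=C/c1ccc(Br)cc1` gives 24500 nM so compound 2 sits level with compound 1. Compound 3 `O=C(CSc1nnc(-c2ccncc2)o1)N/N=C/c1ccccc1F` differs from compound 2 as follows: 2-fluorophenyl in place of 4-bromophenyl on a carbon with a double bond to nitrogen with 2-fluorophenyl in place of 4-bromophenyl on a carbon with a double bond to nitrogen. Going by the values given here, the only measured step is a 1.2-fold higher number from compound 1 to compound 2 (0.08 log units; within the scatter) for bromo in place of chloro on an aromatic carbon, and no measured step covers the present change. No shift beyond the scatter is therefore expected in this assay on this thin evidence. The expected step is a 1.1-fold lower number from compound 2 to compound 3 (0.05 log units; within the scatter) as an estimate only. Compound 3 is estimated at 22000 nM with an expected range of 9000 nM to 50000 nM in these notes.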

Compound 3, half-maximal inhibitory concentration: 24000 nM
Compound 3: middle estimate off by 1.1-fold (0.04 log units), on the low side; the range from low to high includes it.
By their numbers in this assay, from the lowest: compounds 1, 3 and 2 (each within the scatter of the next).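

In this assay, 2-fluorophenyl on the carbon with a double bond to nitrogen matches 4-bromophenyl, with a 1.0-fold lower number from compound 2 to compound 3 (0.01 log units; within the scatter), and 4-chlorophenyl, with a 1.2-fold higher number from compound 1 to compound 3 (0.07 log units; within the scatter). The earlier pair covered only bromo against chloro on the same phenyl pattern, whereas this change alters both the halogen and its printed ring number without leaving the scatter. No measurement bearing on this result is available to explain it. As far as these compounds go, all three compounds carry a halogenated phenyl here, so it remains open whether a phenyl bearing an amine or a carboxylic acid would read differently.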